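This account rests on a few compounds, and the source may have more. Where it says the series, first, only, none or still open, it means among the compounds named here.

Compound 3 `Cc1oc2c3c(ccc2c(=O)c1-c1ccccc1)OC[C@H]1[C@@H]3Nc2ccccc2C1(C)C` in a functional assay on MDA-MB-231 cells (Homo sapiens) for antiproliferative activity, read by MTT assay (a higher number here means a weaker inhibitor, a lower number a stronger inhibitor), returns only a limit, > 100000 nM. Compound 2 `Cc1oc2c3c(ccc2c(=O)c1C)OC[C@H]1[C@@H]3Nc2ccccc2C1(C)C` in this assay likewise returns only a limit, > 100000 nM. Compound 1 `Cc1ccc2c(c1)C(C)(C)[C@H]1COc3ccc4c(=O)c(C)c(C)oc4c3[C@H]1N2` in this assay also gives nothing but a limit, > 100000 nM. With every value in the series resting on the same limit of the assay (the limit of > 100000 nM in this assay, at which 3 of the 3 values shown sit), compound 3 cannot be placed above or below the other two; it simply shares that limit with them. The two measured steps, a step that the two limits leave unreadable from compound 1 to compound 2 and a step that the two limits leave unreadable from compound 2 to compound 3, are both unreadable in size due to the limit of > 100000 nM in this assay, at which 3 of the 3 values shown sit, so neither tells how the methyl or the phenyl on the aromatic carbon moves the read-out.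

Compound 4 `Cc1ccc2c(c1)C(C)(C)[C@H]1COc3ccc4c(=O)c(-c5ccccc5)c(C)oc4c3[C@H]1N2` is compound 3 with methyl in place of hydrogen on an aromatic carbon. Going by the values given here, compound 1 already carries a methyl at that same place on the same ring and shows only a limit, and no measured step with a readable size bears on this change. The step from compound 3 to compound 4 is therefore expected to be unreadable as well, a number no higher from compound 3 to compound 4 (the limit leaves the size open), with compound 4 expected once more at the limit. The estimate for compound 4 in this assay is 100000 nM, with a range from 30000 nM to 300000 nM.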

Compound 4, half-maximal inhibitory concentration: > 100000 nM
Compound 4 ended at the assay's limit (the forecaster's own chance of this, stated with the estimate: 85%); the middle value sits exactly at the limit.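

Neither the step from compound 3 to compound 4 nor the step from compound 1 to compound 4 can be read in this assay because of a shared limit: the limit of > 100000 nM in this assay, at which 4 of the 4 values shown sit. The compounds shown leave open whether methyl or phenyl at these places changes the antiproliferative read-out at all, and how far any compound lies beyond the limit.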